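This account rests on a few compounds, and the source may have more. Where it says the series, first, only, none or still open, it means among the compounds named here.

Compound 1 `COc1ccc(-c2cn(-c3ccc(O)c(C(=O)Nc4cccc(C(F)(F)F)c4)c3)nn2)cc1`: 12%
Compound 2 `COc1ccc(OC)c(-c2cn(-c3ccc(O)c(C(=O)OCCCc4ccccc4)c3)nn2)c1`: 5%
Compound 3 `COC(=O)c1cc(-n2cc(-c3cccc(O)c3)nn2)ccc1O`: 5%

All three compounds were tested in a functional assay on CCRF-CEM cells (Homo sapiens) for inhibition, read by MTT assay, with a stated time of 2 days, tested at 10 uM; a higher number here means more inhibition at the concentration tested (going by the name of the read-out), a lower number less inhibition. In this assay compound 2 gives 5%, and compound 3 gives 5%, the same number at the digits shown. Compound 1 gives 12%, a number that sits within the usual scatter of the other two, so no ordering among the three can be read from these values. The whole measured set therefore describes a low and rather flat level of inhibition.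

Compound 4 `O=C(OCCCc1ccccc1)c1cc(-n2cc(-c3cc(O)ccc3O)nn2)ccc1O` is the next compound to be measured. It differs from compound 2 in one place: 2,5-dihydroxyphenyl in place of 2,5-dimethoxyphenyl on an aromatic carbon. Within the data shown here, no pair of measured compounds differing in a single place is available, so the effect of this particular change has no measured precedent here. Since compound 2 and its two companions all give low numbers in this assay, compound 4 is expected to stay near that level, with no step beyond the scatter in either direction.

Compound 4 is expected to give 7% in this assay, with a range from 0% to 20%. This estimate means a step of a number 2 percentage points higher from compound 2 to compound 4 (within the scatter), expected to remain within the scatter.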

Compound 4, a percentage reported as inhibition, at one concentration (the size of the read-out at that concentration, not a potency): 81%
Estimate against measurement, compound 4: 74 percentage points below, and the stated range ends below it.
By their numbers in this assay, from the lowest: compounds 2, 3 and 1 (each within the scatter of the next); then compound 4.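

Placing 2,5-dihydroxyphenyl in place of 2,5-dimethoxyphenyl on an aromatic carbon of the five-membered aromatic ring with 3 nitrogen gives a number 76 percentage points higher from compound 2 to compound 4 (beyond the scatter) in this assay and lifts the series out of the low, flat level seen so far, showing that the outcome at this position depends strongly on what the attached ring carries. The change itself is modest by count, since the six-membered aromatic ring stays, the group goes from 10 heavy atoms to 8, and hydrogen-bond donors go from 0 to 2 while acceptors stay at 2. Nothing at hand bears on why a change of this kind produces so large a step.

The compounds shown leave open whether both hydroxyl groups are needed, as no compound here carries one hydroxyl and one methoxy on that ring in the same arrangement. They also leave open whether an amine or a fluorine in place of those hydroxyl groups would hold this level, and whether it would survive a carboxylic acid in place of the ester on the shared core.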